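The compounds below may be only part of what the source reports. "The series", "measured", "known", "first", "only" and "open" are said of these compounds alone.

Measured in an ADME assay on a cell-free system (plasma, Rattus norvegicus) for protein binding:
Compound 1 `CNc1nccc(N2CC[C@H](NC(=O)Nc3ccc(CN(C)C)c(C(F)(F)F)c3)C2)n1` gives 91%
Compound 2 `CNc1nccc(N2CC[C@H](NC(=O)Nc3ccc(OC(F)(F)F)cc3)C2)n1` gives 98.1%

Of these two, compound 1 has the larger free share, and its gap to compound 2 lies beyond the usual scatter. Compound 3 (`CNc1nccc(N2CC[C@H](NC(=O)Nc3ccc(CN4CCC4)c(C(F)(F)F)c3)C2)n1`) keeps the core of compound 1 and differs in one place: azetidin-1-yl stands in place of dimethylamino on a saturated chain carbon bound to an aromatic carbon (azetidin-1-yl in place of dimethylamino on a saturated chain carbon bound to an aromatic carbon). For the measured compounds named here, no measured pair shows this exchange, so the data offer no direct guide. The expectation therefore starts from compound 1 (91%), its closest measured relative. The expected change (a 1.1-fold higher unbound fraction from compound 1 to compound 3 (0.05 log units; within the scatter)) is small, within the scatter in this assay and without a firm direction. For compound 3 the estimated value is 90% with an expected range from 82% to 95% in this measurement.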

Compound 3, plasma protein binding: 89.2%
For compound 3 the middle estimate is 1.1-fold (0.03 log units) (unbound fraction) below the measured one; measured number inside the range.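

In this assay the exchange of dimethylamino for azetidin-1-yl on this saturated chain carbon bound to an aromatic carbon gives a step within the scatter (a 1.2-fold higher unbound fraction from compound 1 to compound 3 (0.08 log units; within the scatter)). At this place, then, tying the amine's two carbon arms into a four-membered non-aromatic ring, with one more carbon among its heavy atoms, leaves no change in this assay that can be told from the scatter. Nothing at hand explains this result.

On these data alone, whether a larger ring on the same nitrogen, such as pyrrolidin-1-yl or morpholin-4-yl, or a longer chain between the amine and the aromatic ring would stay as close to compound 1 remains open. So does whether the same exchange behaves alike on any core other than that of compound 1.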